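A 4-Chlorophenyl Group Tested on Two Related Cores

The source may hold more compounds than are shown below. What is called first, only, known or untested is meant among the compounds shown, and "the series" means these compounds.

Compound 1, `O=C1COc2ccc(-c3cccc(NS(=O)(=O)c4ccc(F)cc4)c3)cc2N1`: in a functional assay on HCT-116 cells (Homo sapiens) for antiproliferative activity, read by MTT assay, with a stated time of 72 h (on this read-out lower numbers stand for stronger inhibition and higher numbers for weaker inhibition), compound 1 reaches only the limit of the assay, > 40000 nM.
Compound 2, `O=C1COc2ccc(-c3cccc(NS(=O)(=O)c4ccc(F)cc4)c3)cc2N1c1ccc(Cl)cc1`: in this assay compound 2 gives 23900 nM.
Compound 3, `O=C1COc2ccc(-c3cnc4ccccc4c3)cc2N1`: in this assay compound 3 also reaches only the limit, > 40000 nM.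

The three measured compounds share a bicyclic lactam core that carries a different aromatic group. The change from compound 1 to compound 2 is 4-chlorophenyl in place of hydrogen on an amide-type nitrogen in a ring, and it gives an at least 1.6-fold lower number from compound 1 to compound 2 (0.22 log units; that floor lies within the scatter). Within the data shown here, this is the only step among the measured compounds, and its size is uncertain since the value of compound 1 is a limit, as noted in the limit of > 40000 nM in this assay, at which 2 of the 3 values shown sit.

Compound 4, `O=C1COc2ccc(-c3cnc4ccccc4c3)cc2N1c1ccc(Cl)cc1`, is not yet measured. It stands to compound 3 exactly as compound 2 stands to compound 1: the change is 4-chlorophenyl in place of hydrogen on an amide-type nitrogen in a ring, the same change at the same place. The difference between the core of compound 3 and that of compound 1 is not broken down here.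

For compound 4 the expectation rests on the measured pair alone. Because the step of an at least 1.6-fold lower number from compound 1 to compound 2 (0.22 log units; that floor lies within the scatter) is small and starts from a limit, a similarly small step is expected from compound 3 to compound 4, namely an at least 1.3-fold lower number from compound 3 to compound 4 (0.12 log units; that floor lies within the scatter). Compound 4 is therefore estimated at 30000 nM in this assay, within a range from 10000 nM to 60000 nM, with a real chance that only a limit is reported.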

Compound 4, half-maximal inhibitory concentration: 36100 nM
For compound 4 the middle estimate is 1.2-fold (0.08 log units) below the measured one, and the stated range covers the measured number.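

On the core of compound 3, the 4-chlorophenyl group on the amide-type nitrogen gives an at least 1.1-fold lower number from compound 3 to compound 4 (0.04 log units; that floor lies within the scatter) in this assay. In both pairs the compound with this group gives a measured number where the compound with hydrogen gives only a limit, and the two steps can be set side by side only as floors: the same change on two cores in this assay, an at least 1.6-fold lower number (0.22 log units; that floor lies within the scatter) from compound 1 to compound 2 and an at least 1.1-fold lower number (0.04 log units; that floor lies within the scatter) from compound 3 to compound 4; the limit leaves it open whether they differ. This does not show that the change carries over from one core to the other with a given size, nor that it has a real effect on either core, since each step starts from a limit and neither has a true size: the limit of > 40000 nM in this assay, at which 2 of the 4 values shown sit.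

The compounds shown leave open whether other groups on the same ring nitrogen, such as an unsubstituted phenyl, a benzyl, a 4-methoxyphenyl or a chain ending in an amine, would give the same picture as 4-chlorophenyl on these two cores. They also leave open what this change does on a core where the compound with hydrogen already gives a measured number rather than a limit, which is the case that would allow the size of the step to be read.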